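A few compounds are considered here, and "the series" means these few. Any claim that something is new, unique, unknown or untested is made for them only; others in the source may bear on it.

In a functional assay on CCRF-CEM cells (Homo sapiens) for inhibition, read by MTT assay, with a stated time of 72 h (on this read-out higher numbers stand for weaker inhibition and lower numbers for stronger inhibition), compound 1 `COc1cc(NC(C)CCCNC(=O)Nc2ccc(Br)cc2)c2ncccc2c1` gives 23000 nM, compound 2 `COc1cc(NC(C)CCCNC(=O)NNC(=O)Nc2cccc(F)c2)c2ncccc2c1` gives 98000 nM, and compound 3 `COc1cc(NC(C)CCCNC(=O)Nc2ccc(C(F)(F)F)cc2)c2ncccc2c1` gives 14000 nM. Compound 3 therefore belongs to the low pair of these numbers, with no separation from its partner: the data show a 1.6-fold lower number from compound 1 to compound 3 (0.22 log units; within the scatter), and against the remaining compound a 7.0-fold lower number from compound 2 to compound 3 (0.85 log units; beyond the scatter). Compound 4 `COc1cc(NC(C)CCCNC(=O)Nc2ccc(O)cc2)c2ncccc2c1` has hydroxy in place of trifluoromethyl on an aromatic carbon, (hydroxy in place of trifluoromethyl on an aromatic carbon).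

For the measured compounds named here, only one measured step swaps a group at this same place, and that step, a 1.6-fold lower number from compound 1 to compound 3 (0.22 log units; within the scatter), stays small. Going by the values given here, it exchanges bromo for trifluoromethyl, however, and no measured compound carries hydroxy, so it offers only limited guidance. The steps that replace the whole group on the amide-type nitrogen are larger, at a 4.3-fold higher number from compound 1 to compound 2 (0.63 log units; beyond the scatter), but they change far more of the structure than this swap does. A modest shift towards weaker inhibition seems the likeliest outcome, though the data do not establish its direction. The expected step is a 2.1-fold higher number from compound 3 to compound 4 (0.33 log units; beyond the scatter), close to the edge of the scatter. In this assay, compound 4 is estimated at 30000 nM, with an expected range from 11000 nM to 80000 nM.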

Compound 4, half-maximal inhibitory concentration: 23000 nM
Compound 4: the middle estimate sits 1.3-fold (0.12 log units) above what was measured, and the stated range covers the measured number.
By their numbers in this assay, from the lowest: compounds 3, 1 and 4 (each within the scatter of the next); then compound 2.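

In this assay, the step from trifluoromethyl to hydroxy on the aromatic carbon para to a large group stays within the scatter (a 1.6-fold higher number from compound 3 to compound 4 (0.22 log units; within the scatter)), even though a group of 4 heavy atoms with no hydrogen-bond donor or acceptor gives way to a single oxygen that counts as both. Hydroxy also matches bromo at this place (no change at the digits printed from compound 1 to compound 4 (within the scatter)), so bromo, trifluoromethyl and hydroxy cannot be told apart here, while replacing the whole group on the amide-type nitrogen still gives a step beyond the scatter (a 4.3-fold lower number from compound 2 to compound 4 (0.63 log units; beyond the scatter)). Nothing available explains why these three groups read alike in this assay.

Three groups at one place cannot show whether this position is insensitive in general, and an amine, a carboxylic acid or a longer chain there might still separate from them. The compounds also leave open whether hydroxy would behave in the same way elsewhere on the ring, and whether any change to the chain or the shared core would shift the numbers further.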